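A few compounds are considered here, and "the series" means these few. Any claim that something is new, unique, unknown or untested is made for them only; others in the source may bear on it.

Measured in an ADME assay on Vero cells (Chlorocebus sabaeus) for cytotoxicity; a lower number here means that less compound is tolerated, a higher number that more compound is tolerated:
Compound 1 `Cc1ccc(-c2nc3c(NC4CCCC4)cccn3c2-c2ccnc(NC3CCCC3)n2)cc1`: > 40000 nM
Compound 2 `Fc1ccc(-c2nc3c(NC4CC4)cccn3c2-c2ccnc(NC3CCCC3)n2)cc1`: 33000 nM

Compound 1 stands at > 40000 nM, which is a limit of the assay and not a number. For the measured compounds named here, compound 2 therefore holds the only actual number so far, 33000 nM. Going by the values given here, no step between measured compounds is available to scale the next change.

Compound 3 `Fc1ccc(-c2nc3ccccn3c2-c2ccnc(NC3CCCC3)n2)cc1` carries hydrogen in place of cyclopropylamino on an aromatic carbon of a six-membered aromatic ring with 1 nitrogen, part of a fused or bridged system of two rings (hydrogen in place of cyclopropylamino on an aromatic carbon).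

With compound 2 at 33000 nM as the only reference, no change beyond the scatter is expected in this assay, and the estimated step of a 1.1-fold higher number from compound 2 to compound 3 (0.03 log units; within the scatter) has no firm direction. A report of a limit alone would not be a surprise. For compound 3 the expected value is 35000 nM, with an estimated range of 16000 nM to 70000 nM.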

Compound 3, half-maximal cytotoxic concentration: > 40000 nM
Compound 3: no number, only a limit (the forecaster's own chance of this, stated with the estimate: 45%); middle value at least 1.1-fold (0.05 log units) from the limit.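

In this assay, for the compounds shown here, hydrogen in place of cyclopropylamino on an aromatic carbon gives the only one-place comparison: an at least 1.2-fold higher number from compound 2 to compound 3 (0.08 log units; that floor lies within the scatter). Compound 3 gives > 40000 nM, which is a limit of the assay and not a number, so only a floor of the step can be read, and that floor lies within the usual scatter. Loss of cyclopropylamino at this position therefore brings no visible fall in the tolerated concentration, but the comparison has little room to show a rise: the limit of > 40000 nM in this assay, at which 2 of the 3 values shown sit.

From the compounds shown here alone, whether any group at this position can move the value well away from that limit remains open, for example a methoxy group, a dimethylamino group or a carboxylic acid. Compound 1 differs from compound 2 in more than one place, so it cannot separate the effect of the group at this position.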